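Compound 2 and Its Form Without Drawn Configuration

This account rests on a few compounds, and the source may have more. Where it says the series, first, only, none or still open, it means among the compounds named here.

In a physicochemical assay for solubility, in phosphate buffer, measured as kinetic solubility, with a stated time of 1 h, at pH 7.4 (on this read-out lower numbers stand for lower solubility and higher numbers for higher solubility), compound 1 (`CC(C)(c1cc([C@@]23CCOC[C@@H]2C3)nc(-c2cccc(O)c2)n1)S(C)(=O)=O`) reads 148 ug/mL and compound 3 (`CCNC(=O)Nc1ccc(-c2nc(C(C)(C)S(C)(=O)=O)cc([C@]34CCOC[C@H]3C4)n2)cc1`) reads 74 ug/mL while compound 2 (`Oc1cccc(-c2nccc([C@@]34CCOC[C@@H]3C4)n2)c1`) reads 123 ug/mL and sits within the scatter of both. Compound 4 (`Oc1cccc(-c2nccc(C34CCOCC3C4)n2)c1`) departs from compound 2 only in how it is drawn (the two compounds have the same atoms and bonds; at least one stereo element is drawn with a configuration in one of them and without one in the other: 2 of 2 stereo elements differ; a stereocentre at a saturated ring carbon is drawn S in compound 2 and without a configuration in compound 4; a stereocentre at a saturated ring carbon is drawn R in compound 2 and without a configuration in compound 4). Within the data shown here, the one measured step (a 1.2-fold lower number from compound 1 to compound 2 (0.08 log units; within the scatter)) lies within the scatter and concerns hydrogen in place of 1-methyl-1-(methylsulfonyl)ethyl on an aromatic carbon, so it bears only loosely on this change. Among the measured compounds shown here, no measured pair tests drawn configuration. No step beyond the scatter is therefore expected in this assay for this change. The expected step (a 1.0-fold lower number from compound 2 to compound 4 (0.01 log units; within the scatter)) stays within the scatter. Compound 4 is estimated at 120 ug/mL with an expected range of 70 ug/mL to 200 ug/mL on this read-out.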

Compound 4, solubility: 102 ug/mL
Estimate against measurement, compound 4: 1.2-fold (0.07 log units) above; the range from low to high includes it.
By their numbers in this assay, from the lowest: compounds 3, 4, 2 and 1 (each within the scatter of the next).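

In this assay, the pair gives the first direct test of drawn configuration at these two stereocentres, with a 1.2-fold lower number from compound 2 to compound 4 (0.08 log units; within the scatter). Removing the drawn configuration from both stereocentres therefore leaves no step beyond the scatter, something compounds 1 and 3 could not show, as both are drawn with a configuration. The comparison rests on one distinction: the fact that one of compounds 2 and 4 is drawn with a defined configuration and the other without, at the place where they differ

As far as these compounds go, how the form with the opposite drawn configuration would read remains open. So does whether the same would hold with an amine or a carboxylic acid on the shared core.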